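The source may hold more compounds than are shown below. What is called first, only, known or untested is meant among the compounds shown, and "the series" means these compounds.

Measured compounds in this series:
compound 1 `Cc1c(C(=O)NCc2cccc(C(F)(F)F)c2)cnn1-c1ccc(Cl)cc1` — 600 nM
compound 2 `Cc1c(C(=O)NCc2cccc(O)c2)cnn1-c1ccc(Cl)cc1` — > 3000 nM
compound 3 `Cc1c(C(=O)NCc2cccc(S(C)(=O)=O)c2)cnn1-c1ccc(Cl)cc1` — 2100 nM

In a functional assay on cells for antagonist activity at C-C chemokine receptor type 1 (Homo sapiens), read by FLIPR and calcium flux (a lower number here means a stronger inhibitor, a higher number a weaker inhibitor), compound 1 gives 600 nM, the lowest number shown. Compound 3 gives 2100 nM in this assay. For compound 2 this assay returns only a limit, > 3000 nM, at the limit of > 3000 nM in this assay, at which 1 of the 3 values shown sits. Both measured steps away from compound 1 raise the number: an at least 5.0-fold higher number from compound 1 to compound 2 (0.69 log units; beyond the scatter) and a 3.5-fold higher number from compound 1 to compound 3 (0.54 log units; beyond the scatter). Between the two weaker analogues there is an at least 1.4-fold lower number from compound 2 to compound 3 (0.15 log units; that floor lies within the scatter).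

Compound 4 `Cc1c(C(=O)NCc2ccccn2)cnn1-c1ccc(Cl)cc1` carries pyridin-2-yl in place of 3-hydroxyphenyl on a saturated chain carbon bound to an amide-type nitrogen. Among the measured compounds shown here, no measured step covers this change; what bears on it is only that compound 2 sits at the limit, so a value reachable in this assay would read as a downward step. A modest step is expected. Compound 4 is estimated at 2200 nM (range 700 nM to 6000 nM), an expected at least 1.3-fold lower number from compound 2 to compound 4 (0.13 log units; that floor lies within the scatter).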

Compound 4, half-maximal inhibitory concentration: > 3000 nM
Compound 4: no number, only a limit (the forecaster's own chance of this, stated with the estimate: 35%); middle value at least 1.3-fold (0.13 log units) away from the limit.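

Compound 2 and compound 4 both return only a limit in this assay, so no step between them can be read: the limit of > 3000 nM in this assay, at which 2 of the 4 values shown sit.

On these data alone, whether pyridin-2-yl in place of 3-hydroxyphenyl shifts the number in this assay, and in which direction, stays open.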